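Fluorine on the benzyl group of a chalcone triazole

The source may report more compounds than this note shows. Statements on the series, on what has been measured and on what is new or still open speak of the compounds shown alone.

In a functional assay on MIA PaCa-2 cells (Homo sapiens) for inhibition, read by MTT assay, with a stated time of 48 h, tested at 10 uM (on this read-out lower numbers stand for less inhibition of growth and higher numbers for more inhibition of growth at the one concentration tested), compound 2 `O=C(/C=C/c1ccc(OCc2cn(Cc3ccccc3)nn2)cc1)c1ccc(Br)cc1` gives 44%, and compound 1 `C#CCOc1ccc(/C=C/C(=O)c2ccc(Br)cc2)cc1` gives 34%, two numbers that sit within the usual scatter of each other. Compound 3 `O=C(/C=C/c1ccc(OCc2cn(Cc3ccccc3F)nn2)cc1)c1ccc(Br)cc1` differs from compound 2 by fluoro in place of hydrogen on an aromatic carbon. Going by the values given here, no measured pair shows what such a change does here, so in this assay a step of no more than the scatter is expected in either direction. For compound 3 the expected result in this assay is 45%, with a range from 30% to 60%, which means an expected step of a number 1 percentage points higher from compound 2 to compound 3 (within the scatter).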

Compound 3, percent growth inhibition at one concentration: 28%
Beside the measured number, compound 3's estimate is 17 percentage points above it, and the stated range ends above it.
By their numbers in this assay, from the lowest: compounds 3, 1 and 2 (each within the scatter of the next, the first and the last beyond it).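

In this assay, going from benzyl to 2-fluorobenzyl gives a number 16 percentage points lower from compound 2 to compound 3 (beyond the scatter), so this place on the aromatic ring responds to a single fluoro. Compounds 1 and 2 differ by far more than one atom and could not show this. Nothing available explains the step.

Going by these compounds, it remains open whether the step belongs to fluoro itself or to any group at this place, which a chloro or methoxy group there would help to separate. On these data alone, it is also open whether fluoro on another carbon of the ring gives a similar step.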